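A few compounds are considered here, and "the series" means these few. Any claim that something is new, unique, unknown or untested is made for them only; others in the source may bear on it.

Measured so far:
compound 1, `O=S(=O)(Nc1ccc(-c2nc3ccccc3o2)cc1)c1cccs1`: > 63000 nM
compound 2, `O=S(=O)(Nc1ccc(-c2nc3ccccc3o2)cc1)c1ccc(F)c(C(F)(F)F)c1`: > 63000 nM

Both values come from an assay on isolated protein for inhibition of malate dehydrogenase, mitochondrial (Sus scrofa), with stated times of 45 min and 30 min; a higher number here means a weaker inhibitor, a lower number a stronger inhibitor. For compound 1 the value > 63000 nM is a limit of this assay, not a number. For compound 2 the value > 63000 nM is likewise a limit. Compound 1 thus stands at the edge of what this assay can report, as the limit of > 63000 nM in this assay, at which 2 of the 2 values shown sit, shows, and compound 2 offers no order against it. The unmeasured compound 3, `Cc1ccccc1S(=O)(=O)Nc1ccc(-c2nc3ccccc3o2)cc1`, differs from compound 1 in one place: 2-methylphenyl in place of thiophen-2-yl on a sulfonyl sulfur. Among the measured compounds shown here, no step between measured compounds is known, so the direction of this change cannot be read from the data. Because the limit of > 63000 nM in this assay, at which 2 of the 2 values shown sit, places compound 1 at the limit, any weaker inhibition would also appear only as a limit in this assay. Compound 3 is expected to give 70000 nM in this assay, within 25000 nM to 200000 nM. The step this estimate means, a step that the limit leaves unreadable from compound 1 to compound 3, is expected to be none beyond the scatter.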

Compound 3, half-maximal inhibitory concentration: > 63000 nM
Compound 3: no number, only a limit; the forecaster's own chance of this, stated with the estimate: 80%; the middle value does not contradict the limit.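

Like compound 1, compound 3 returns only a limit in this assay, not a number, so no step between compound 1 and compound 3 can be read: the limit of > 63000 nM in this assay, at which 3 of the 3 values shown sit. The compounds shown leave open whether any group on the sulfonyl sulfur gives measurable inhibition in this assay.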